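A few compounds are considered here, and "the series" means these few. Any claim that something is new, unique, unknown or untested is made for them only; others in the source may bear on it.

Measured so far in an assay on HEK293 cells for inhibition of neurogenic locus notch homolog protein 1 (Homo sapiens), read by a luciferase reporter and resazurin assay, with a stated time of 16 h; on this read-out higher numbers stand for weaker inhibition and lower numbers for stronger inhibition:
compound 1 `CC1=C(C(=O)OC2CCN(C(=O)OC(C)(C)C)CC2)C(c2cccc(Br)c2)C2=C(CC(C)(C)CC2=O)N1` — > 10000 nM
compound 2 `CC1=C(C(=O)OCc2ccc(C(C)(C)C)cc2)C(c2cccc(Br)c2)C2=C(CC(C)(C)CC2=O)N1` — 4270 nM
compound 3 `CC1=C(C(=O)OCC2CCN(C(=O)OC(C)(C)C)CC2)C(c2cccc(C#N)c2)C2=C(CC(C)(C)CC2=O)N1` — 220 nM

The value for compound 1 is a limit of this assay, not a number. Compound 2 gives a measured number, and compound 3 gives the lowest of the two numbers in hand; the gap from compound 3 up to compound 2 lies beyond the scatter. Among the measured compounds shown here, compounds 2 and 3 differ in more than one place, so no single step between them is drawn.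

The next compound is compound 4 `CC1=C(C(=O)OCC2CCN(C(=O)OC(C)(C)C)CC2)C(c2cccc(C(C)C)c2)C2=C(CC(C)(C)CC2=O)N1`. Relative to compound 3 the change is isopropyl in place of cyano on an aromatic carbon, with the ester side unchanged. For the measured compounds named here, no measured pair shows an exchange of this kind, so the direction rests on nothing firmer than the spread of the three numbers above. The step from compound 3 to compound 4 in this assay is expected to run toward a higher number, likely beyond the scatter but well short of the limit, estimated as a 3.2-fold higher number from compound 3 to compound 4 (0.50 log units; beyond the scatter). On that basis compound 4 is expected to give 700 nM in this assay, with a range from 150 nM to 4000 nM.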

Compound 4, half-maximal inhibitory concentration: 3320 nM
Estimate against measurement, compound 4: 4.7-fold (0.68 log units) below, and the stated range covers the measured number.
By their numbers in this assay, from the lowest: compound 3; then compounds 4 and 2 (each within the scatter of the next). At a limit, above all of these: compound 1.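

Among the compounds shown here, with the ester side held fixed, the change from 3-cyanophenyl to 3-isopropylphenyl gives a 15-fold higher number from compound 3 to compound 4 (1.18 log units; beyond the scatter) in this assay, and this is the first comparison that differs in one place only. The earlier compounds shown here differ on the ester side and on the aromatic ring together, so they could not assign any change in number to this position; here the group on that aromatic carbon alone moves the number beyond the scatter, and the nitrile is the better of the two groups compared. The step still stops short of the limit, which in this set belongs to compound 1 alone: the limit of > 10000 nM in this assay, at which 1 of the 4 values shown sits.

With only a nitrile and an isopropyl compared on this ester side, the data cannot tell which difference between the two groups accounts for the step, and a single pair gives no trend. From the compounds shown here alone, it also remains open where a methoxy, an amine, a carboxylic acid or a bromine at the same place would fall with this ester side, and whether the step keeps its size on a different ester side.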